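Sulfur to oxygen and halogen swap on a diamine core

This account rests on a few compounds, and the source may have more. Where it says the series, first, only, none or still open, it means among the compounds named here.

Compound 3 `Nc1cc(N)c2nc(-c3ccccc3)c(Sc3ccc(Cl)c(Cl)c3)nc2c1` gives the lowest of the two plain numbers in a functional assay on DU-145 cells (Homo sapiens) for inhibition, read by sulforhodamine B assay, with a stated time of 48 h (on this read-out higher numbers stand for weaker inhibition of growth and lower numbers for stronger inhibition of growth), namely 3800 nM. Compound 2 `COc1ccc(Sc2nc3cc(N)cc(N)c3nc2-c2ccccc2)cc1` gives 33100 nM, and the step of an 8.7-fold lower number from compound 2 to compound 3 (0.94 log units; beyond the scatter) is modest. Compound 1 `Nc1cc(N)c2nc(-c3ccccc3)c(Oc3ccc(Cl)c(Cl)c3)nc2c1` reaches only a limit, < 100000 nM, so that the limit of < 100000 nM in this assay, at which 1 of the 3 values shown sits, leaves the steps from compound 1 unreadable. Compound 4 `Nc1cc(N)c2nc(-c3ccccc3)c(Oc3ccc(F)cc3)nc2c1` differs from compound 3 by 4-fluorophenoxy in place of (3,4-dichlorophenyl)sulfanyl on an aromatic carbon. The measured step that bears on this is an 8.7-fold lower number from compound 2 to compound 3 (0.94 log units; beyond the scatter), which shows that changing the ring on the sulfur shifts the number well beyond the scatter; the change of sulfur to oxygen itself is unreadable. Compound 4 is therefore expected to show a weaker, higher number, estimated at 25000 nM (range 6000 nM to 100000 nM), a step of a 6.6-fold higher number from compound 3 to compound 4 (0.82 log units; beyond the scatter).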

Compound 4, concentration for total growth inhibition: 87100 nM
Estimate against measurement, compound 4: 3.5-fold (0.54 log units) below; the range from low to high includes it.
By their numbers in this assay, from the lowest: compound 3; then compound 2; then compound 4.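

In this assay, the position on the aromatic carbon proves sensitive to the whole group it carries: 4-fluorophenoxy brings a 23-fold higher number from compound 3 to compound 4 (1.36 log units; beyond the scatter), and the same group brings a smaller change, a 2.6-fold higher number from compound 2 to compound 4 (0.42 log units; beyond the scatter). Each of these steps changes both the sulfur and the ring together, so neither isolates the effect of oxygen. The size of the step depends on which sulfur-linked group leaves.

Compound 1 stands at a limit, so its step to compound 4 cannot be read: the limit of < 100000 nM in this assay, at which 1 of the 4 values shown sits. Going by these compounds, whether an amine in place of the sulfur, or a longer chain carrying the ring, would keep growth inhibition remains open.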